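Tolerance of a Methoxyphenyl Amide Series in Human Monocytic Cells

This account rests on a few compounds, and the source may have more. Where it says the series, first, only, none or still open, it means among the compounds named here.

In a toxicity assay on THP-1 cells (Homo sapiens) for inhibition (a higher number here means that more compound is tolerated, a lower number that less compound is tolerated), three related amides have so far been tested, all built on a shared core carrying an amide linked to a substituted phenyl ring. Compound 1 `Cn1c(-c2ccc(C#N)cc2)cnc1NC(=O)c1ccc(F)cc1` reaches only a limit in this assay, > 50000 nM. Compound 2 `COc1ccc(-c2cnc(NC(=O)c3cccc(OC)c3)n2C)cc1` also gives only a limit, > 100000 nM. Compound 3 `COc1ccc(-c2cnc(NC(=O)c3ccc(F)cc3)[nH]2)cc1` likewise stops at a limit, > 100000 nM. So compound 2 stands where the other two stand: no number is known for it, only a limit, as recorded in the limit of > 100000 nM in this assay, at which 2 of the 3 values shown sit, and (the limit of > 50000 nM in this assay, at which 1 of the 3 values shown sits). None of the three compounds was toxic enough within the tested range for a half-maximal cytotoxic concentration to be found.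

Compound 4 `COc1ccc(-c2cnc(NC(=O)c3ccc(Br)cc3)n2C)cc1` has not yet been measured in this assay. It differs from compound 2 in one place: 4-bromophenyl in place of 3-methoxyphenyl on a carbonyl carbon. Among the measured compounds shown here, no step between two measured compounds is available to say how such a change affects cell tolerance here. Given that compound 2 sits at a limit, > 100000 nM, the step from compound 2 to compound 4 is expected to be none beyond the scatter, a number no higher from compound 2 to compound 4 (the limit leaves the size open). Compound 4 is therefore estimated to be tolerated at about 100000 nM, with a likely range from 30000 nM to 300000 nM, most probably again reported only as a limit.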

Compound 4, half-maximal cytotoxic concentration: > 100000 nM
Compound 4: only a limit was reported; the forecaster's own chance of this, stated with the estimate: 85%; the middle value sits exactly at the limit.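

On these data alone, compound 2 and compound 4 both stop at a limit in this assay, so no step can be read between them, and the effect of 4-bromophenyl in place of 3-methoxyphenyl stays unknown. The compounds shown leave open the concentration at which any of them would reach a half-maximal cytotoxic effect, with most results stopping at one limit: the limit of > 100000 nM in this assay, at which 3 of the 4 values shown sit.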